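Adding a trifluoromethyl group to compound 2

This account rests on a few compounds, and the source may have more. Where it says the series, first, only, none or still open, it means among the compounds named here.

Of the compounds shown here, three sharing one core have been tested in a functional assay on the whole organism with Scenedesmus acutus as the target, read by spectrophotometry; on this read-out lower numbers stand for stronger inhibition and higher numbers for weaker inhibition. Compound 1 `O=c1c2c(sn1-c1ccc(C(F)(F)F)cc1)CCCC2` gives 55000 nM. Compound 2 `O=c1c2c(sn1-c1ccc(Cl)cc1)CCCC2` gives 16600 nM, and compound 3 `O=c1c2c(sn1-c1ccc([N+](=O)[O-])cc1)CCCC2` gives 13200 nM. Compound 2 therefore sits level with compound 3, as swapping chloro for nitro gives only a 1.3-fold lower number from compound 2 to compound 3 (0.10 log units; within the scatter).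

Compound 4 `O=c1c2c(sn1-c1ccc(Cl)cc1C(F)(F)F)CCCC2` keeps the chloro group of compound 2 and gains a substituent: trifluoromethyl in place of hydrogen on an aromatic carbon. This is trifluoromethyl in place of hydrogen on an aromatic carbon, ortho to a large group and meta to a chloro group.

Within the data shown here, no measured step adds a group at that carbon, so the evidence is indirect. Among the measured compounds shown here, the only guide is compound 1, the one tested compound carrying trifluoromethyl. Replacing that group with chloro gives a 3.3-fold lower number from compound 1 to compound 2 (0.52 log units; beyond the scatter), and replacing it with nitro gives a 4.2-fold lower number from compound 1 to compound 3 (0.62 log units; beyond the scatter). Both steps are modest, and both involve a swap on a different carbon rather than an addition. They suggest that gaining trifluoromethyl may raise the number somewhat, though a change within the scatter would be no surprise.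

The expected step is a 2.1-fold higher number from compound 2 to compound 4 (0.32 log units; beyond the scatter). For compound 4 the estimated value in this assay is 35000 nM, with an expected range from 12000 nM to 100000 nM.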

Compound 4, half-maximal inhibitory concentration: 44700 nM
Estimate against measurement, compound 4: 1.3-fold (0.11 log units) below, within the range that was stated.
By their numbers in this assay, from the lowest: compounds 3 and 2 (each within the scatter of the next); then compounds 4 and 1 (each within the scatter of the next).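

Among these compounds, compounds 2 and 4 differ in one place only, so this pair gives the first direct reading of what happens when a group is added to this carbon rather than swapped on another. In this assay placing trifluoromethyl on the aromatic carbon ortho to a large group and meta to a chloro group gives a 2.7-fold higher number from compound 2 to compound 4 (0.43 log units; beyond the scatter) and this modest step, beyond the scatter, means weaker inhibition, so this carbon does not simply accept the new group without any effect on the read-out. Nothing measured alongside these numbers accounts for the rise, so the result records the size of the change and offers no explanation for it.

Trifluoromethyl is the only group seen at this carbon, so it remains open whether a fluoro group, a methyl group, a methoxy group or an amine in the same place would also raise the number, leave it level or lower it. On these data alone, it is equally open whether adding trifluoromethyl here would have a similar effect when the chloro group is replaced by the nitro group of compound 3.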